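A few compounds are considered here, and "the series" means these few. Any claim that something is new, unique, unknown or untested is made for them only; others in the source may bear on it.

Read in a functional assay on HeLa cells (Homo sapiens) for antiproliferative activity, read by sulforhodamine B assay, with a stated time of 48 h (a lower number here means a stronger inhibitor of growth, a higher number a weaker inhibitor of growth), compound 1 (`Sc1nnc(C2=C(Cl)c3ccccc3CCC2)n1-c1ccccc1`) gives 5500 nM and compound 2 (`Cc1cc2c(cc1C)C(Cl)=C(c1nnc(Nc3ccccc3)s1)CCC2`) gives 4920 nM as values within the scatter of each other. Compound 3 (`Cc1ccc(-c2nnc(C3=C(Cl)c4cc(C)c(C)cc4CCC3)o2)cc1`) gives 679 nM as the lowest of the three numbers. That value lies beyond the scatter from both others, which makes compound 3 the strongest inhibitor of growth measured so far. Compound 4 (`Cc1cc2c(cc1C)C(Cl)=C(c1nnc(-c3cccc(Cl)c3)o1)CCC2`) has not yet been measured. It carries 3-chlorophenyl in place of 4-methylphenyl on an aromatic carbon of the five-membered aromatic ring with 2 nitrogen and 1 oxygen (3-chlorophenyl in place of 4-methylphenyl on an aromatic carbon), and the rest of compound 3 is unchanged. Within the data shown here, no two measured compounds differ in one place only, so this swap has no direct precedent. Among the measured compounds shown here, compound 3 (679 nM) is also the only measured compound with this ring, which leaves it as the sole anchor for the estimate. The expected change (a 1.3-fold higher number from compound 3 to compound 4 (0.10 log units; within the scatter)) is small, with no step beyond the scatter anticipated in this assay and any drift expected toward a slightly higher number. For compound 4 the estimated value is 850 nM with an expected range from 280 nM to 2600 nM for repeat measurements.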

Compound 4, concentration for 50% growth inhibition: 5940 nM
The estimate for compound 4 lay 7.0-fold (0.84 log units) below the measured number; measured number above the stated range.
By their numbers in this assay, from the lowest: compound 3; then compounds 2, 1 and 4 (each within the scatter of the next).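

In this assay, among these compounds, this is the first comparison that isolates a single position, and the aryl group on the aromatic carbon of the five-membered aromatic ring with 2 nitrogen and 1 oxygen proves to matter: 3-chlorophenyl in place of 4-methylphenyl gives an 8.7-fold higher number from compound 3 to compound 4 (0.94 log units; beyond the scatter). Compound 3, at 679 nM, and compound 4, at 5940 nM, share everything else, and the two groups match in heavy-atom count, in ring type and in hydrogen-bond donors and acceptors, so activity here is sensitive to a change that leaves those counts untouched. No measurement available for these compounds bears on the reason for this step.

The step changes two things at once, the substituent on the phenyl ring and its place there, and the compounds shown do not separate the chlorine from the position. Going by these compounds, how the number responds to an unsubstituted phenyl, or to a methoxy group or an amine on that ring, also remains open.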